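This account rests on a few compounds, and the source may have more. Where it says the series, first, only, none or still open, it means among the compounds named here.

Of the compounds shown here, two built on a shared core have been measured so far, and they differ in a single group on an aromatic carbon. In a functional assay on HCT-116 cells (Homo sapiens) for cytotoxicity, read by fluorescence, with a stated time of 72 h (on this read-out higher numbers stand for weaker inhibition and lower numbers for stronger inhibition), compound 1 `CC(C)c1n[nH]c2c(NCc3ccc(-c4ccccn4)cc3)nc(NCC(N)CO)nc12` gives 781 nM, while compound 2 `CC(C)c1n[nH]c2c(NCc3ccc(-c4ccccn4)cc3)nc(N3CCNCC3)nc12` gives 88 nM, the lower of the two numbers. The next compound, compound 3 `COc1ccc(CNc2nc(NCc3ccc(-c4ccccn4)cc3)c3[nH]nc(C(C)C)c3n2)cc1`, keeps the core and changes the same place, with (4-methoxybenzyl)amino in place of piperazin-1-yl on an aromatic carbon. Going by the values given here, only one measured step bears on this change, namely an 8.9-fold lower number from compound 1 to compound 2 (0.95 log units; beyond the scatter). In that step, piperazin-1-yl arrived at this same place and replaced an open chain, so removing it again points towards a higher number. This is thin evidence, since neither measured compound carries an aromatic ring in the group at this place. Among the compounds with values here, a higher number in this assay is therefore expected, of about the same size as the one measured step, although a much smaller change cannot be ruled out. The expected step is a 9.1-fold higher number from compound 2 to compound 3 (0.96 log units; beyond the scatter). The estimated value for compound 3 is 800 nM, with an expected range from 170 nM to 3800 nM.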

Compound 3, half-maximal inhibitory concentration: 17400 nM
The estimate for compound 3 lay 22-fold (1.34 log units) below the measured number; the whole stated range lies below it.
By their numbers in this assay, from the lowest: compound 2; then compound 1; then compound 3.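

The group at this place, on an aromatic carbon between two ring nitrogen atoms, can shift the cytotoxicity read-out much further than the first pair showed: in this assay, (4-methoxybenzyl)amino in place of piperazin-1-yl gives a 200-fold higher number from compound 2 to compound 3 (2.30 log units; beyond the scatter), which is a large step. The change also sets the new group apart from the open chain, with a 22-fold higher number from compound 1 to compound 3 (1.35 log units; beyond the scatter) in the same cells, so among these three compounds, the group with the six-membered aromatic ring of carbon only gives the weakest inhibition, and losing piperazin-1-yl alone does not set how far the number rises. The data offer no measurement that explains either step.

The entering group differs from both earlier groups in its aromatic ring, its methoxy group and its size, and these three compounds cannot separate those features from one another. Plain benzylamino, without the methoxy group, would test the role of that group, while morpholin-4-yl, with an oxygen in place of one piperazine nitrogen, would show how much that nitrogen contributes to the low number of compound 2.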